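Replacing the 3,4-dihydroxyphenyl group of compound 2

The source may report more compounds than this note shows. Statements on the series, on what has been measured and on what is new or still open speak of the compounds shown alone.

For the measured compounds named here, in a functional assay on KBVIN cells (Homo sapiens) for antiproliferative activity, read by sulforhodamine B assay, with a stated time of 3 days (on this read-out higher numbers stand for an effect only at larger amounts of compound and lower numbers for an effect already at smaller amounts), compound 1 (`CCC1=C(O)c2c(oc(-c3ccc(OC)cc3C)cc2=O)C(CC)(CC)C1=O`) gives 2.62 uM and compound 2 (`CCC1=C(O)c2c(oc(-c3ccc(O)c(O)c3)cc2=O)C(CC)(CC)C1=O`) gives 5.41 uM, the higher of the two numbers so far. Compound 3 (`CCC1=C(O)c2c(oc(-c3ccc(F)c(C)c3)cc2=O)C(CC)(CC)C1=O`) keeps the shared core and changes only the aryl group of compound 2: 4-fluoro-3-methylphenyl in place of 3,4-dihydroxyphenyl on an aromatic carbon. Going by the values given here, one measured step bears on this place, a 2.1-fold higher number from compound 1 to compound 2 (0.31 log units; beyond the scatter), a modest step that brought in 3,4-dihydroxyphenyl in place of 4-methoxy-2-methylphenyl. Compound 3, like compound 1, carries a methyl-bearing phenyl group without hydroxyl groups, so a reversal of similar size is expected, toward a lower number. That single step is thin evidence, and a different substitution pattern could behave differently. The expected change is a 2.0-fold lower number from compound 2 to compound 3 (0.30 log units; within the scatter). Compound 3 is estimated at 2.7 uM, within an expected range of 1.2 uM to 6.5 uM.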

Compound 3, concentration for half-maximal effect: 1.62 uM
Compound 3: the middle estimate sits 1.7-fold (0.22 log units) above what was measured; the range from low to high includes it.
By their numbers in this assay, from the lowest: compounds 3 and 1 (each within the scatter of the next); then compound 2.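

In this assay, a 3.3-fold lower number from compound 2 to compound 3 (0.52 log units; beyond the scatter), so a second aryl group at this position, with 0 hydrogen-bond donors against 2 for 3,4-dihydroxyphenyl, also reads lower than compound 2. Compound 3 and compound 1 cannot be separated: a 1.6-fold lower number from compound 1 to compound 3 (0.21 log units; within the scatter), which means that 4-fluoro-3-methylphenyl and 4-methoxy-2-methylphenyl serve about equally in this assay despite their different substitution. No independent evidence is available to explain why compound 2 reads higher than the other two compounds.

The two hydroxyl groups have not been isolated from the rest of the aryl group, since both replacements also bring in a methyl group and another substituent. On these data alone, how a plain phenyl, a single hydroxyl group, an aminophenyl group or a carboxylic acid on the ring would read at this position remains open.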